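A formyl-to-hydroxymethyl swap at the assay limit

The source may report more compounds than this note shows. Statements on the series, on what has been measured and on what is new or still open speak of the compounds shown alone.

Values measured in a functional assay on SEM cells (Homo sapiens) for cytotoxicity, with a stated time of 72 h; on this read-out lower numbers stand for an effect already at smaller amounts and higher numbers for an effect only at larger amounts of compound:
compound 1 `C=C[C@@](C)(/C=C/c1ccc(O)cc1)CCC=O`: > 36600 nM (a limit)
compound 2 `C=C[C@@](C)(/C=C/c1ccc(O)cc1)CC/C=C/C#N`: > 36600 nM (a limit)
compound 3 `C=C[C@@](C)(/C=C/c1ccc(O)cc1)CC/C=C(\C)C=O`: > 36600 nM (a limit)

All three entries are limits of the assay and not numbers, so compound 3 has no readable rank in the set. Compound 4 `C=C[C@@](C)(/C=C/c1ccc(O)cc1)CC/C=C(\C)CO` differs from it by one change: hydroxymethyl in place of formyl on a double-bonded chain carbon bound to a double-bonded chain carbon and a saturated chain carbon with hydroxymethyl in place of formyl on a double-bonded chain carbon bound to a double-bonded chain carbon and a saturated chain carbon.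

Among the compounds with values here, three measured steps bear on this only loosely: a step that the two limits leave unreadable from compound 1 to compound 2 and a step that the two limits leave unreadable from compound 1 to compound 3 and a step that the two limits leave unreadable from compound 2 to compound 3. None of them makes this swap, and none has a readable size. No step size can be carried over because the limit of > 36600 nM in this assay, at which 3 of the 3 values shown sit, leaves nothing to measure from. The expected change is a step that the limit leaves unreadable from compound 3 to compound 4 and no shift beyond the scatter is foreseen in this assay in either direction. The estimate for compound 4 is 40000 nM with an expected range from 20000 nM to 80000 nM and the most likely report is again only a limit.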

Compound 4, half-maximal effective concentration: > 36600 nM
Compound 4 gave a limit, no number; the forecaster's own chance of this, stated with the estimate: 80%; the middle value lies beyond the limit too.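

No new step can be read among compound 1, compound 2, compound 3 and compound 4 in this assay, because all of them give only a limit: the limit of > 36600 nM in this assay, at which 4 of the 4 values shown sit.

The compounds shown leave open whether hydroxymethyl in place of formyl, or any other change among them, alters the read-out at all.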